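The source may report more compounds than this note shows. Statements on the series, on what has been measured and on what is new or still open speak of the compounds shown alone.

Measured compounds:
- compound 1, `CC(CCCCOc1ccccc1CN(C)C(=O)c1ccc(-c2ccco2)cc1)C(=O)O`: 3 mL/min/kg
- compound 2, `C[C@H](CCCOc1ccccc1CN(C)C(=O)c1ccc(-c2ccco2)cc1)CC(=O)O`: 0.3 mL/min/kg

Within the data shown here, in an ADME assay on the whole organism (strain CD-1) for pharmacokinetics, with Mus musculus as the target, at a dose of 3 mg/kg by the intravenous route (on this read-out higher numbers stand for fast clearance and lower numbers for slow clearance), compound 1 gives 3 mL/min/kg, the highest of the two numbers known so far. Among the measured compounds shown here, compound 2, whose acid-bearing chain is arranged differently on the same core, gives 0.3 mL/min/kg, and the one measured step, a 10-fold lower number from compound 1 to compound 2 (1.00 log units; beyond the scatter), shows that rearranging this chain can move the clearance well beyond the scatter.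

Compound 3, `C/C(=C\COc1ccccc1CN(C)C(=O)c1ccc(-c2ccco2)cc1)CCC(=O)O`, has not been measured. It differs from compound 1 in a single place: 4-carboxy-2-methylbut-1-en-1-yl in place of 4-carboxypentyl on a saturated chain carbon bound to an oxygen on an aromatic ring. The chain keeps its length and its acid, but gains a double bond close to the oxygen on the aromatic ring and moves its methyl group.

For the measured compounds named here, the only measured step bears on this change indirectly: it shows that altering the acid chain of compound 1 shifted clearance by a modest amount, in the downward direction. The change to compound 3 is of a different kind, so the direction is uncertain, and the expected step of a 1.3-fold higher number from compound 1 to compound 3 (0.12 log units; within the scatter) is put near the scatter. Compound 3 is therefore estimated at 4 mL/min/kg, within a range from 1.5 mL/min/kg to 12 mL/min/kg.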

Compound 3, clearance: 15 mL/min/kg
Beside the measured number, compound 3's estimate is 3.8-fold (0.57 log units) below it; measured number outside the range, above it.
By their numbers in this assay, from the lowest: compound 2; then compound 1; then compound 3.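

In this assay, replacing the 4-carboxypentyl of compound 1 with 4-carboxy-2-methylbut-1-en-1-yl gives a 5.0-fold higher number from compound 1 to compound 3 (0.70 log units; beyond the scatter), so a change to this chain can also raise clearance, although it keeps the same count of heavy atoms and the acid. The earlier step, a 10-fold lower number from compound 1 to compound 2 (1.00 log units; beyond the scatter), had shown only a fall, so this position can now be seen to move the read-out in both directions from compound 1. The two chain variants also lie far apart, with a 50-fold higher number from compound 2 to compound 3 (1.70 log units; beyond the scatter), which means that the arrangement of the chain alone spans a wide range of clearance in these three compounds, and no measurement here accounts for that spread.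

Going by these compounds, the double bond and the moved methyl group arrive together in compound 3, so their separate shares in the rise remain unknown. Also open, on these data alone, is how clearance would respond to a longer chain carrying the double bond, or to a tetrazole or a primary amide in place of the carboxylic acid.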